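Swapping a fluorophenyl for a furan on the ketone

A few compounds are considered here, and "the series" means these few. Any claim that something is new, unique, unknown or untested is made for them only; others in the source may bear on it.

Three compounds share one core, a methylated pyrrole that carries a hydroxamic acid arm on one side and an unsaturated ketone on the other. Compound 1 `Cn1cc(/C=C/C(=O)c2ccccc2F)cc1/C=C/C(=O)NO` gives 3400 nM in an assay on isolated protein for inhibition of histone deacetylase HD1B (Zea mays); on this read-out lower numbers stand for stronger inhibition and higher numbers for weaker inhibition. For the measured compounds named here, compound 3 `CC/C(=C\c1cc(/C=C/C(=O)NO)n(C)c1)C(=O)c1ccccc1` gives 4500 nM in this assay, a number that lies within the usual scatter of the one for compound 1. Compound 2 `Cn1cc(/C=C/C(=O)c2ccc(-c3ccccc3)cc2)cc1/C=C/C(=O)NO` gives 31800 nM in this assay, clearly higher than compound 1 and beyond that scatter.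

Compound 4 `Cn1cc(/C=C/C(=O)c2ccco2)cc1/C=C/C(=O)NO` has not yet been tested. It differs from compound 1 in one place: furan-2-yl in place of 2-fluorophenyl on a carbonyl carbon. The rest of the molecule, including the hydroxamic acid arm, is unchanged. Going by the values given here, no pair of measured compounds shows the effect of such a swap on its own, so the expectation rests on the closeness of compound 1 and compound 3 alone.

Compound 4 is therefore expected to land close to compound 1, with a step of a 1.0-fold higher number from compound 1 to compound 4 (0.01 log units; within the scatter) that does not go beyond the scatter. The estimate for compound 4 in this assay is 3500 nM, within a range from 1500 nM to 8500 nM.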

Compound 4, half-maximal inhibitory concentration: 19700 nM
Compound 4: middle estimate off by 5.6-fold (0.75 log units), on the low side; the measured number lies above the stated range.
By their numbers in this assay, from the lowest: compounds 1 and 3 (each within the scatter of the next); then compounds 4 and 2 (each within the scatter of the next).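

With the rest of the molecule held fixed, furan-2-yl in place of 2-fluorophenyl on a carbonyl carbon gives a 5.8-fold higher number from compound 1 to compound 4 (0.76 log units; beyond the scatter) in this assay and so means weaker inhibition, beyond the usual scatter. This pair shows directly that the ring on this carbonyl carbon affects the read-out, and that this ring cannot be exchanged freely. The change alters ring size, fluorine and oxygen content all at once, and no available data explain the loss.

A thiophen-2-yl group on the same carbonyl carbon would keep the five-membered ring while replacing its oxygen with sulfur, which would help show whether the ring size or the hetero atom goes with the higher number. From the compounds shown here alone, whether a pyridin-2-yl ring or a 2-chlorophenyl group would stay close to compound 1 also remains open.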